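This account rests on a few compounds, and the source may have more. Where it says the series, first, only, none or still open, it means among the compounds named here.

Measured in a functional assay on KB cells (Homo sapiens) for antiproliferative activity, read by MTT assay; a lower number here means a stronger inhibitor, a higher number a weaker inhibitor:
Compound 1 `c1ccc2c(c1)ccn2-c1nc(N2CCNCC2)nc2ccccc12`: 4 ug/mL
Compound 2 `CN1CCN(c2nc(-n3ccc4ccccc43)c3ccccc3n2)CC1`: 4.9 ug/mL

Only these two numbers are available, and they lie within the scatter of each other, so compound 2 cannot be ranked against compound 1. Compound 3 `c1ccc(N2CCN(c3nc(-n4ccc5ccccc54)c4ccccc4n3)CC2)nc1` is still unmeasured. It keeps the core of compound 2 and carries pyridin-2-yl in place of methyl on an amine nitrogen in a ring.

Among the compounds with values here, one measured step bears on this position: a 1.2-fold higher number from compound 1 to compound 2 (0.09 log units; within the scatter). That step is small and only exchanges hydrogen for methyl on the same nitrogen. Within the data shown here, no measured compound carries a ring there, so the data give only weak guidance for the new group. With no evidence for a direction, no shift beyond the scatter is expected in this assay, though the uncertainty is wide. The expected step is a 1.1-fold lower number from compound 2 to compound 3 (0.04 log units; within the scatter). For compound 3 the estimated value is 4.5 ug/mL, with an expected range from 1.5 ug/mL to 13 ug/mL.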

Compound 3, half-maximal inhibitory concentration: 50 ug/mL
The estimate for compound 3 lay 11-fold (1.05 log units) below the measured number, outside the stated range (above it).
By their numbers in this assay, from the lowest: compounds 1 and 2 (each within the scatter of the next); then compound 3.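

In this assay, the group on the amine nitrogen of the six-membered non-aromatic ring proves able to move the number a long way: pyridin-2-yl in place of methyl gives a 10-fold higher number from compound 2 to compound 3 (1.01 log units; beyond the scatter), and pyridin-2-yl in place of hydrogen gives a 13-fold higher number from compound 1 to compound 3 (1.10 log units; beyond the scatter). Within the data shown here, both steps lie beyond the scatter and point towards a weaker inhibitor, whereas the only earlier step at this nitrogen, methyl in place of hydrogen, gave a 1.2-fold higher number from compound 1 to compound 2 (0.09 log units; within the scatter), which lies within it. Among these three compounds, then, hydrogen and methyl cannot be told apart at this position, while the six-membered aromatic ring stands clearly apart from both, and nothing at hand gives a reason for this loss.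

With a single ring-bearing compound, the data leave open whether the loss goes with the ring itself, with its nitrogen or simply with the larger group. Phenyl, benzyl or a longer chain such as n-butyl on the same nitrogen would begin to separate these readings, and whether any other group at this position could give a lower number than hydrogen or methyl also remains unknown.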